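Substituent swap on the benzylic chain carbon of the core

The source may hold more compounds than are shown below. What is called first, only, known or untested is meant among the compounds shown, and "the series" means these compounds.

Compound 1 `O=C(O)c1ccccc1-c1ccc(CCc2ncc(CC3CCCCC3)[nH]2)cc1` and compound 2 `O=C(O)c1ccccc1-c1ccc(CCc2ncc(Cc3cccc(F)c3F)[nH]2)cc1` share one core and differ only in the group on a saturated chain carbon bound to an aromatic carbon. In an in vitro functional assay on cells for agonist activity at Bombesin receptor subtype-3 (Mus musculus), read by luminescence and calcium flux (a lower number here means that less compound is needed, a higher number that more compound is needed for the effect), compound 1 gives 7.3 nM, and compound 2 gives 8 nM. The step of a 1.1-fold higher number from compound 1 to compound 2 (0.04 log units; within the scatter) shows that cyclohexyl giving way to 2,3-difluorophenyl at this place leaves the number essentially unchanged. Compound 2 thus holds the higher of the two numbers, with compound 1 nearest to it and within the scatter, so no order between the two can be claimed.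

Compound 3 `N#Cc1ccccc1Cc1cnc(CCc2ccc(-c3ccccc3C(=O)O)cc2)[nH]1` differs from compound 2 by 2-cyanophenyl in place of 2,3-difluorophenyl on a saturated chain carbon bound to an aromatic carbon. Within the data shown here, the only measured step at this place, a 1.1-fold higher number from compound 1 to compound 2 (0.04 log units; within the scatter), stayed within the scatter, and it is the sole guide available: there a saturated ring became an aromatic one without consequence, whereas here one aromatic ring is exchanged for another carrying a nitrile. On that basis the expected step in this assay is a 1.5-fold higher number from compound 2 to compound 3 (0.18 log units; within the scatter), not beyond the scatter. Compound 3 is accordingly estimated at 12 nM, with a range from 4 nM to 40 nM.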

Compound 3, half-maximal effective concentration: 642 nM
Compound 3: the middle estimate sits 54-fold (1.73 log units) below what was measured; measured number outside the range, above it.
By their numbers in this assay, from the lowest: compounds 1 and 2 (each within the scatter of the next); then compound 3.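

Working notes on the chain position: this place is not indifferent to the group it carries, since 2-cyanophenyl in place of 2,3-difluorophenyl in this assay gives an 80-fold higher number from compound 2 to compound 3 (1.90 log units; beyond the scatter), and the same group in place of cyclohexyl gives an 88-fold higher number from compound 1 to compound 3 (1.94 log units; beyond the scatter), whereas cyclohexyl and 2,3-difluorophenyl lie within the scatter of each other. The tolerance seen with compounds 1 and 2 therefore does not extend to every six-membered ring here: the groups exchanged in compound 2 and compound 3 match in heavy-atom count and each holds one six-membered aromatic ring of carbon only, so neither that count nor the ring type settles the number. The entering group adds a nitrile with its triple bond and a hydrogen-bond acceptor and the leaving group takes away two fluorines, but no measurement on these compounds bears on why the step is so large.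

Still open, going by these compounds, is whether the step follows the arrival of the nitrile or the departure of the fluorines. Plain phenyl, 2-fluorophenyl and 2-methoxyphenyl at this place would separate these readings, and a nitrile elsewhere on the ring, as in 3-cyanophenyl, would test whether its location counts.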